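Swapping the pyrimidine for a thiadiazole on compound 3

The compounds below may be only part of what the source reports. "The series", "measured", "known", "first", "only" and "open" are said of these compounds alone.

Of the compounds shown here, three have been measured in a functional assay on C6 cells (Rattus norvegicus) for cytotoxicity, read by MTT assay, with a stated time of 24 h, tested at 6 ug/mL; a lower number here means a stronger effect, a higher number a weaker effect of the compound at the concentration tested. Compound 3 `Cc1ccc(-c2cs/c(=N/NC(=O)CSc3ncccn3)n2-c2ccccc2)cc1` gives 93.2%, the highest of the three numbers and therefore the weakest effect. Within the data shown here, compound 1 `Cc1nnc(SCC(=O)N/N=c2/scc(-c3ccc(F)cc3)n2-c2ccccc2)s1` gives 74.3%, and compound 2 `COc1ccc(-c2cs/c(=N/NC(=O)CSc3nnc(C)s3)n2-c2ccccc2)cc1` gives 57.9%; the one step between them, a number 16.4 percentage points lower from compound 1 to compound 2 (beyond the scatter), concerns a different part of the molecule, the group on the aromatic ring, and so does not speak to the change considered here. Compound 4 `Cc1ccc(-c2cs/c(=N/NC(=O)CSc3nnc(C)s3)n2-c2ccccc2)cc1` differs from compound 3 in one place: 5-methyl-1,3,4-thiadiazol-2-yl in place of pyrimidin-2-yl on a sulfur. Among the measured compounds shown here, no measured pair isolates this exchange. What can be said is that compound 1 and compound 2, which both carry the 5-methyl-1,3,4-thiadiazol-2-yl group, give lower numbers than compound 3 with its pyrimidin-2-yl. On that basis compound 4 is expected to land below compound 3, with a step of about a number 21.2 percentage points lower from compound 3 to compound 4 (beyond the scatter). The estimate for compound 4 in this assay is 72%, expected to fall between 52% and 92%.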

Compound 4, a percentage reported as activity, at one concentration (the size of the read-out at that concentration, not a potency): 65.9%
Beside the measured number, compound 4's estimate is 6.1 percentage points above it; the range from low to high includes it.
By their numbers in this assay, from the lowest: compounds 2, 4 and 1 (each within the scatter of the next, the first and the last beyond it); then compound 3.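

Compound 3 and compound 4 now isolate the exchange on the sulfur: in this assay, a number 27.3 percentage points lower from compound 3 to compound 4 (beyond the scatter), so 5-methyl-1,3,4-thiadiazol-2-yl in place of pyrimidin-2-yl gives a stronger effect at the concentration tested. With 5-methyl-1,3,4-thiadiazol-2-yl in place, methyl on the aromatic carbon cannot be told apart from either methoxy or fluoro, as a number 8 percentage points higher from compound 2 to compound 4 (within the scatter) and a number 8.4 percentage points lower from compound 1 to compound 4 (within the scatter), even though methoxy and fluoro differ from each other beyond the scatter. Nothing available explains why the exchange on the sulfur changes the read-out.

The compounds shown leave open whether the exchange has a similar effect with fluoro or methoxy on the aromatic carbon. They also leave open how an aminopyrimidin-2-yl group or a plain phenyl group on the sulfur would compare.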